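Purine glycinamides in the mouse tail flick test

A few compounds are considered here, and "the series" means these few. Any claim that something is new, unique, unknown or untested is made for them only; others in the source may bear on it.

Measured compounds:
compound 1, `N=C(N)NCCC[C@H](NC(=O)CN(c1nc(Cl)nc2[nH]cnc12)C1CC1)C(=O)O`: 7.19%
compound 2, `O=C(CN(c1ncnc2c1ncn2C1CCCCO1)C1CC1)N[C@@H](CCC(=O)OCc1ccccc1)C(=O)OCc1ccccc1`: 14.1%

Of the compounds shown here, two have been measured in a functional assay on the whole organism (Tail, strain ICR) with Mus musculus as the target, in the tail flick test, with a stated time of 150 min, at a dose of 25 umol/kg by the oral route; a lower number here means a weaker effect, a higher number a stronger effect of the compound at the dose given. Compound 1 `N=C(N)NCCC[C@H](NC(=O)CN(c1nc(Cl)nc2[nH]cnc12)C1CC1)C(=O)O` gives 7.19%. Compound 2 `O=C(CN(c1ncnc2c1ncn2C1CCCCO1)C1CC1)N[C@@H](CCC(=O)OCc1ccccc1)C(=O)OCc1ccccc1` gives 14.1%, the higher of the two numbers, though the gap to compound 1 lies within the scatter of this kind of measurement, so the two cannot be ranked against each other.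

Compound 3 `CC[C@H](C)[C@H](NC(=O)CN(c1ncnc2c1ncn2C1CCCCO1)C1CC1)C(=O)OCc1ccccc1` has not yet been measured in this assay. It differs from compound 2 in one place: sec-butyl in place of 2-(benzyloxycarbonyl)ethyl on a saturated chain carbon bound to an amide-type nitrogen and a carbonyl carbon. Among the measured compounds shown here, no step between two measured compounds is available to show what such a change does, so the expectation for compound 3 rests only on the low numbers of compound 1 and compound 2.

Compound 3 is expected to give 12%, within a range from 3% to 30%, in this assay. The step from compound 2 to compound 3 is estimated as a number 2.1 percentage points lower from compound 2 to compound 3 (within the scatter), a change not expected to exceed the scatter.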

Compound 3, a percentage reported as activity, at one dose (the size of the read-out at that dose, not a potency): 16.4%
Beside the measured number, compound 3's estimate is 4.4 percentage points below it; low and high end bracket the measured number.
By their numbers in this assay, from the lowest: compounds 1, 2 and 3 (each within the scatter of the next).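

Among the compounds shown here, this is the first step between two measured compounds that differ in one place: in this assay, sec-butyl in place of 2-(benzyloxycarbonyl)ethyl on a saturated chain carbon bound to an amide-type nitrogen and a carbonyl carbon gives a number 2.3 percentage points higher from compound 2 to compound 3 (within the scatter). At this place, then, a group of 12 heavy atoms carrying a six-membered aromatic ring of carbon only and 2 hydrogen-bond acceptors, and a group of 4 heavy atoms with no ring and no acceptors, cannot be told apart by this read-out at the dose given, so neither that ring nor those acceptors are required for a number of this size. Nothing available explains this outcome.

The compounds shown leave open whether a carboxylic acid, an amine or a longer chain at this place, with the rest of compound 3 kept, would shift the number beyond the scatter. They also leave open whether the equivalence of sec-butyl and 2-(benzyloxycarbonyl)ethyl would persist at a higher oral dose, where the read-out might stand further from these low numbers.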